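A few compounds are considered here, and "the series" means these few. Any claim that something is new, unique, unknown or untested is made for them only; others in the source may bear on it.

Measured compounds in an assay on microsomes from liver for inhibition of 3-hydroxy-3-methylglutaryl-coenzyme A reductase (Rattus norvegicus), read by scintillation counting, with stated times of 0.5 h and 0.75 h; a higher number here means a weaker inhibitor, a lower number a stronger inhibitor:
compound 1 `Cc1ccc(CNC(=O)c2nc(-c3ccc(F)cc3)n(CC[C@@H](O)C[C@@H](O)CC(=O)O)c2C2CC2)cc1` gives 1.7 nM;
compound 2 `O=C(O)C[C@H](O)C[C@H](O)CCn1c(-c2ccc(F)cc2)nc(C(=O)NCc2cccc(F)c2)c1C1CC1` gives 1.2 nM;
compound 3 `COc1cccc(CNC(=O)c2nc(-c3ccc(F)cc3)n(CC[C@@H](O)C[C@@H](O)CC(=O)O)c2C2CC2)c1` gives 1.2 nM.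

Compound 3 matches compound 2 at the digits shown, and its step from compound 1 is small: a 1.4-fold lower number from compound 1 to compound 3 (0.15 log units; within the scatter). Compound 4 `Cc1cccc(CNC(=O)c2nc(-c3ccc(F)cc3)n(CC[C@@H](O)C[C@@H](O)CC(=O)O)c2C2CC2)c1` is reached from compound 3 by methyl in place of methoxy on an aromatic carbon. The closest comparison is no change at the digits printed from compound 2 to compound 3 (within the scatter), which exchanged one group on the same aromatic carbon without moving the number; the remaining steps, a 1.4-fold lower number from compound 1 to compound 2 (0.15 log units; within the scatter) and a 1.4-fold lower number from compound 1 to compound 3 (0.15 log units; within the scatter), also stayed within the scatter. The entering methyl is the group compound 1 carries as 4-methylphenyl. No shift beyond the scatter is therefore expected in this assay: a 1.1-fold higher number from compound 3 to compound 4 (0.03 log units; within the scatter). Compound 4 is estimated at 1.3 nM, with a range from 0.6 nM to 2.8 nM.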

Compound 4, half-maximal inhibitory concentration: 7.2 nM
The estimate for compound 4 lay 5.5-fold (0.74 log units) below the measured number; the whole stated range lies below it.
By their numbers in this assay, from the lowest: compounds 2, 3 and 1 (each within the scatter of the next); then compound 4.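

Exchanges on this aromatic carbon are not all silent, as the earlier compounds had suggested: methyl in place of methoxy gives a 6.0-fold higher number from compound 3 to compound 4 (0.78 log units; beyond the scatter) and methyl in place of fluoro gives a 6.0-fold higher number from compound 2 to compound 4 (0.78 log units; beyond the scatter), although methoxy and fluoro stood level. The position of the methyl also counts, since 3-methylphenyl in place of 4-methylphenyl gives a 4.2-fold higher number from compound 1 to compound 4 (0.63 log units; beyond the scatter). Nothing given here speaks to the reason for these steps. The compounds shown leave open whether a chloro, hydroxyl or ethyl group on this carbon would side with methyl or with methoxy and fluoro.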